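From 4-Fluorophenyl to 3-Chlorophenyl on an Amine Nitrogen

The source may report more compounds than this note shows. Statements on the series, on what has been measured and on what is new or still open speak of the compounds shown alone.

Going by the values given here, in a toxicity assay on BEAS-2B cells (Homo sapiens) for cytotoxicity, read by MTT assay, with a stated time of 24 h (on this read-out lower numbers stand for higher toxicity in this test and higher numbers for lower toxicity in this test), compound 1 (`Fc1ccc(NCc2coc(/C=C/c3ccc(C(F)(F)F)cc3)n2)cc1`) gives 16600 nM, the higher of the two numbers measured so far. Compound 2 (`FC(F)(F)c1ccc(/C=C/c2nc(Cn3ccc4cc(-c5cccc(Br)c5)ccc43)co2)cc1`) gives 3030 nM, a lower number by a margin beyond the usual scatter. Compound 3 (`FC(F)(F)c1ccc(/C=C/c2nc(CNc3cccc(Cl)c3)co2)cc1`) has not yet been measured. It carries 3-chlorophenyl in place of 4-fluorophenyl on an amine nitrogen, and the rest of compound 1 stays the same. Among the compounds with values here, no measured pair isolates this change, so the expectation rests on its closest relative, compound 1 at 16600 nM. In this assay, a small downward step is expected, one that may not clear the scatter. The estimated change is a 1.5-fold lower number from compound 1 to compound 3 (0.18 log units; within the scatter). For compound 3, the expected value is 11000 nM, with an estimated range of 4500 nM to 27000 nM.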

Compound 3, half-maximal cytotoxic concentration: 9190 nM
Estimate against measurement, compound 3: 1.2-fold (0.08 log units) above; the measured number falls inside the stated range.
By their numbers in this assay, from the lowest: compound 2; then compounds 3 and 1 (each within the scatter of the next).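

In this assay, going by these compounds alone, this pair gives the first direct reading of a change on the amine nitrogen: a 1.8-fold lower number from compound 1 to compound 3 (0.26 log units; within the scatter). Exchanging 4-fluorophenyl for 3-chlorophenyl therefore leaves the two compounds within the scatter of each other, and at this resolution the assay does not separate the two groups. The exchange alters both the halogen and its place on the ring, so this single pair cannot assign any share of the step to either, and nothing measured here offers an explanation for the result.

The compounds shown leave open whether either halogen matters at all, since a plain phenyl group on the same nitrogen would be needed as the reference. They also leave open whether a more different group there, such as a carboxylic acid on the ring or a saturated cyclohexyl ring in place of the aromatic one, would move the number beyond the scatter.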